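This account rests on a few compounds, and the source may have more. Where it says the series, first, only, none or still open, it means among the compounds named here.

Measured compounds:
compound 1 `Cc1ccc(C(=O)CSc2nnc(C)n2N2C(=O)c3ccccc3C2=O)cc1` — > 200000 nM
compound 2 `Cc1nnc(SCc2ccccc2Cl)n1N1C(=O)c2ccccc2C1=O` — > 200000 nM
compound 3 `C#CCSc1nnc(CC)n1N1C(=O)c2ccccc2C1=O` — > 200000 nM

In a functional assay on HepG2 cells (Homo sapiens) for cytotoxicity, read by MTT assay, with a stated time of 48 h (on this read-out lower numbers stand for stronger inhibition and higher numbers for weaker inhibition), compound 1 reaches only a limit of the assay, > 200000 nM. Compound 2 likewise stands at a limit, > 200000 nM. Compound 3 also sits at a limit, > 200000 nM; it cannot be placed relative to the other two, since all three values are the limit of > 200000 nM in this assay, at which 3 of the 3 values shown sit. Among the compounds with values here, the single measured step, a step that the two limits leave unreadable from compound 1 to compound 2, is accordingly unreadable in size.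

Compound 4 `CCOC(=O)CSc1nnc(CC)n1N1C(=O)c2ccccc2C1=O` differs from compound 3 by ethoxycarbonyl in place of ethynyl on a saturated chain carbon bound to a sulfur. Within the data shown here, no measured step covers a change of this kind, and the whole series so far gives only limits. The step from compound 3 to compound 4 is therefore expected to be a step that the limit leaves unreadable from compound 3 to compound 4, with compound 4 expected again at a limit of this assay: estimate 250000 nM, range 100000 nM to 1000000 nM.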

Compound 4, half-maximal inhibitory concentration: > 200000 nM
Compound 4: no number, only a limit (the forecaster's own chance of this, stated with the estimate: 85%); the middle value is on the limit's open side.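

No step can be read between compound 3 and compound 4, as both give only a limit: the limit of > 200000 nM in this assay, at which 4 of the 4 values shown sit.

The compounds shown leave open how any of the four ranks against another in this assay.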